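The source may hold more compounds than are shown below. What is called first, only, known or untested is meant among the compounds shown, and "the series" means these compounds.

Of the compounds shown here, two have numbers so far in a functional assay on MCF7 cells (Homo sapiens) for antiproliferative activity, read by MTT assay, with a stated time of 72 h; on this read-out higher numbers stand for weaker inhibition and lower numbers for stronger inhibition. Compound 1 `COc1ncc(-c2ccc3c(c2)N(C2CCCCC2)C(=O)CO3)cc1NS(=O)(=O)c1ccc(F)cc1` gives 30100 nM and compound 2 `O=C1COc2ccc(-c3cnc(Cl)c(NS(=O)(=O)c4ccc(F)cc4)c3)cc2N1c1ccc(Cl)cc1` gives 32800 nM. These two values lie within the scatter of each other, so compound 2 stands alongside compound 1 on the numbers shown, with no order between them. The next structure is compound 3 `COc1ncc(-c2ccc3c(c2)N(c2ccc(Cl)cc2)C(=O)CO3)cc1NS(=O)(=O)c1ccc(F)cc1`, which differs from compound 2 in one group: methoxy in place of chloro on an aromatic carbon. This puts methoxy in place of chloro on an aromatic carbon, next to the ring nitrogen and ortho to a ((4-fluorophenyl)sulfonyl)amino group. Going by the values given here, no measured pair isolates this change, so its size cannot be read directly. Compound 1 also carries methoxy on that carbon and gives 30100 nM, although it differs from compound 3 elsewhere. That value gives no sign of a large shift in this assay, so nothing beyond the scatter is expected, and the estimated change is a 1.2-fold lower number from compound 2 to compound 3 (0.07 log units; within the scatter). Compound 3 is estimated at 28000 nM, with an expected range of 9000 nM to 65000 nM.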

Compound 3, half-maximal inhibitory concentration: 27600 nM
The estimate for compound 3 lay 1.0-fold (0.01 log units) above the measured number, and the stated range covers the measured number.
By their numbers in this assay, from the lowest: compounds 3, 1 and 2 (each within the scatter of the next).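

In this assay, the position now has its first pair that differs in one place: a 1.2-fold lower number from compound 2 to compound 3 (0.07 log units; within the scatter), so methoxy in place of chloro on this aromatic carbon, next to the ring nitrogen and ortho to a ((4-fluorophenyl)sulfonyl)amino group, stays within the scatter. With methoxy held on that carbon, the second pair gives a 1.1-fold lower number from compound 1 to compound 3 (0.04 log units; within the scatter) for 4-chlorophenyl in place of cyclohexyl on the amide-type nitrogen in a ring, also within the scatter, which compound 1 and compound 2 could not show on their own since they differ in two places. No measurement at hand bears on why neither change goes beyond the scatter.

From the compounds shown here alone, whether an amine or a carboxylic acid on that aromatic carbon, or a longer alkyl chain on the amide-type nitrogen, would give a step beyond the scatter stays open. Also open is whether either place can shift the number in this assay at all, since both steps shown are within the scatter.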